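A few compounds are considered here, and "the series" means these few. Any claim that something is new, unique, unknown or untested is made for them only; others in the source may bear on it.

Going by the values given here, in a functional assay on DU-145 cells (Homo sapiens) for inhibition, read by trypan blue exclusion, with a stated time of 72 h (a higher number here means a weaker inhibitor, a lower number a stronger inhibitor), compound 1 (`Cn1c(=O)c(S(=O)(=O)c2ccc(F)cc2F)cc2cnc(Nc3cccc4[nH]ccc34)nc21`) gives 750 nM and compound 2 (`Cn1c(=O)c(S(=O)(=O)c2ccc(F)cc2F)cc2cnc(Nc3ccc4sccc4c3)nc21`) gives 500 nM, so compound 2 stands level with the only other measured compound. Compound 3 (`Cn1c(=O)c(S(=O)(=O)c2ccc(F)cc2F)cc2cnc(Nc3ccncn3)nc21`) carries pyrimidin-4-yl in place of 1-benzothiophen-5-yl on a nitrogen on an aromatic ring. Among the compounds with values here, one measured step bears on this change at the same place, a 1.5-fold lower number from compound 1 to compound 2 (0.18 log units; within the scatter), but it offers only a loose guide, since no measured compound lacks a five-membered ring there. A moderately higher number is therefore expected, with wide uncertainty, a 3.0-fold higher number from compound 2 to compound 3 (0.48 log units; beyond the scatter). Compound 3 is estimated at 1500 nM, with an expected range of 400 nM to 6000 nM.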

Compound 3, half-maximal inhibitory concentration: 50000 nM
For compound 3 the middle estimate is 33-fold (1.52 log units) below the measured one; measured number outside the range, above it.
By their numbers in this assay, from the lowest: compounds 2 and 1 (each within the scatter of the next); then compound 3.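

In this assay the change to pyrimidin-4-yl gives a 100-fold higher number from compound 2 to compound 3 (2.00 log units; beyond the scatter) and also a 67-fold higher number from compound 1 to compound 3 (1.82 log units; beyond the scatter) and so shows that this place on the nitrogen is far from indifferent. The earlier step between 1H-indol-4-yl and 1-benzothiophen-5-yl stayed within the scatter and gave no sign of such sensitivity. Nothing at hand accounts for the loss. The compounds shown leave open whether the loss goes with the missing five-membered ring or with the ring nitrogens. A plain phenyl group or a pyridinyl group at this place would help separate the two.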